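The source may report more compounds than this note shows. Statements on the series, on what has been measured and on what is new or still open speak of the compounds shown alone.

In a functional assay on U-251 cells (Homo sapiens) for antiproliferative activity, read by MTT assay, with a stated time of 24 h (on this read-out lower numbers stand for stronger inhibition and higher numbers for weaker inhibition), three compounds on one shared core have been read so far. Compound 1 `COc1cc(OC)c(-c2coc3cc(OCC(=O)c4cccc(C(F)(F)F)c4)ccc3c2=O)cc1OC` reads > 10000 nM as a limit of the assay and not a number. Compound 2 `COc1cc(OC)c(-c2coc3cc(OCc4ccccc4Br)ccc3c2=O)cc1OC` likewise reads > 10000 nM as a limit. Within the data shown here, compound 3 `COc1cc(OC)c(-c2coc3cc(OCc4ccc(C(F)(F)F)cc4)ccc3c2=O)cc1OC` gives 3750 nM and holds the only true number of the set. It stands ahead of both others: an at least 2.6-fold lower number from compound 1 to compound 3 (0.42 log units; beyond the scatter) and an at least 2.6-fold lower number from compound 2 to compound 3 (0.42 log units; beyond the scatter) are only floors on the step size, while a step that the two limits leave unreadable from compound 1 to compound 2 cannot be sized.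

Compound 4 `COc1cc(OC)c(-c2coc3cc(OCc4cccc(C(F)(F)F)c4)ccc3c2=O)cc1OC` carries 3-(trifluoromethyl)phenyl in place of 4-(trifluoromethyl)phenyl on a saturated chain carbon bound to an oxygen on an aromatic ring and has yet to be read. The measured steps swap other groups, so they give no size for this one. Compound 3 alone gives a true number at 3750 nM so a small rise is thought likelier than a fall. Among the measured compounds shown here, the expected result is a 1.3-fold higher number from compound 3 to compound 4 (0.12 log units; within the scatter) and no step far beyond the scatter is expected. For compound 4 the estimate is 5000 nM with an expected range from 1800 nM to 13000 nM.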

Compound 4, half-maximal inhibitory concentration: > 10000 nM
Compound 4 was reported as a limit (the forecaster's own chance of this, stated with the estimate: 35%); at least 2.0-fold (0.30 log units) between middle value and limit.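

In this assay, the change from 4-(trifluoromethyl)benzyl to 3-(trifluoromethyl)benzyl keeps the same atoms, joined differently, yet it gives an at least 2.6-fold higher number from compound 3 to compound 4 (0.42 log units; beyond the scatter). Compound 4 reads > 10000 nM, which is a limit of the assay and not a number, so this step is only a floor on the true size. The earlier steps swapped one group for a different group at this place, whereas this pair shows that the reading is sensitive to where the trifluoromethyl group sits on the benzyl ring, and it leaves compound 3 alone with a true number: the limit of > 10000 nM in this assay, at which 3 of the 4 values shown sit.

The steps from compound 1 and compound 2 to compound 4 cannot be read, so these three cannot be ranked against one another. On these data alone, whether a nitrile or a carboxylic acid in place of the trifluoromethyl group of compound 3 would give a lower or a higher number stays open.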